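Thiophene for methoxyphenyl in the bromoacrylamide pair

The compounds below may be only part of what the source reports. "The series", "measured", "known", "first", "only" and "open" are said of these compounds alone.

Measured so far:
compound 1 `Nc1cccc(-c2cn3nc(-c4cccs4)sc3n2)c1` – > 250000 nM
compound 2 `C=C(Br)C(=O)Nc1cccc(-c2cn3nc(-c4cccc(OC)c4)sc3n2)c1` – 500 nM

Two compounds carry results in a functional assay on FM3A cells (Mus musculus) for inhibition, read by cell counting, with a stated time of 2 days; on this read-out higher numbers stand for weaker inhibition and lower numbers for stronger inhibition. Compound 1 gives only a limit of the assay, > 250000 nM. That result for compound 1 sits at the limit of > 250000 nM in this assay, at which 1 of the 2 values shown sits. Going by the values given here, compound 2 gives 500 nM, the only number in this assay so far. Among the compounds with values here, compound 1 and compound 2 differ in more than one place, so no single step stands between them; their two values show only that one is a limit and the other a number.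

Compound 3 `C=C(Br)C(=O)Nc1cccc(-c2cn3nc(-c4cccs4)sc3n2)c1` is not yet measured. It keeps the rest of compound 2 and differs by thiophen-2-yl in place of 3-methoxyphenyl on an aromatic carbon. Within the data shown here, no measured step covers this change, so the expected step from compound 2 to compound 3 in this assay is a 1.6-fold higher number from compound 2 to compound 3 (0.20 log units; within the scatter), a slight weakening that need not exceed the scatter. Compound 3 is estimated at 800 nM, within 200 nM to 4000 nM.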

Compound 3, half-maximal inhibitory concentration: 370 nM
The estimate for compound 3 lay 2.2-fold (0.33 log units) above the measured number, within the range that was stated.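

In this assay, thiophen-2-yl in place of 3-methoxyphenyl on the aromatic carbon next to the ring nitrogen and next to the ring sulfur gives a 1.4-fold lower number from compound 2 to compound 3 (0.13 log units; within the scatter), so the two aromatic groups cannot be told apart at this position in this read-out. Going by these compounds alone, the first single-place comparison for the (1-bromoethenyl)carbonyl group on the nitrogen, with thiophen-2-yl held constant, gives an at least 670-fold lower number from compound 1 to compound 3 (2.82 log units; beyond the scatter), a large step. Compound 1 supplies a limit and not a number to that step: the limit of > 250000 nM in this assay, at which 1 of the 3 values shown sits.

On these data alone, whether the large step needs the bromine stays open: an acetyl or a plain acryloyl on that nitrogen would separate the bromine from the rest of the group. Also open, as far as these compounds go, is how this position responds to non-aromatic groups, such as a morpholine or a carboxylic acid in place of thiophen-2-yl.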